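Replacing pyridin-4-yl with 4-methylphenyl on the carbonyl

This account rests on a few compounds, and the source may have more. Where it says the series, first, only, none or still open, it means among the compounds named here.

In a functional assay on MDA-MB-231 cells (Homo sapiens) for antiproliferative activity, read by MTT assay, with a stated time of 72 h (on this read-out higher numbers stand for weaker inhibition and lower numbers for stronger inhibition), compound 1 (`CC(=O)O[C@H]1CC[C@]2(C)[C@H](CC[C@@](C)(O)[C@H]2CC[C@@H]2C(C)=CC[C@H]3[C@H](CC[C@]3(C)O)C2(C)C)OC1(C)C`) gives 38000 nM and compound 2 (`CC1=CC[C@H]2[C@H](CC[C@]2(C)O)C(C)(C)[C@@H]1CC[C@H]1[C@]2(C)CC[C@H](OC(=O)c3ccncc3)C(C)(C)O[C@H]2CC[C@@]1(C)O`) gives 18000 nM as the lower of the two numbers. Among the measured compounds shown here, the only measured step is a 2.1-fold lower number from compound 1 to compound 2 (0.32 log units; beyond the scatter) for pyridin-4-yl in place of methyl on a carbonyl carbon, a modest step beyond the scatter.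

Compound 3 (`CC1=CC[C@H]2[C@H](CC[C@]2(C)O)C(C)(C)[C@@H]1CC[C@H]1[C@]2(C)CC[C@H](OC(=O)c3ccc(C)cc3)C(C)(C)O[C@H]2CC[C@@]1(C)O`) differs from compound 2 by 4-methylphenyl in place of pyridin-4-yl on a carbonyl carbon with 4-methylphenyl in place of pyridin-4-yl on a carbonyl carbon. For the measured compounds named here, each of the two groups is one six-membered aromatic ring, and no measured pair tests this exchange directly. The step of a 2.1-fold lower number from compound 1 to compound 2 (0.32 log units; beyond the scatter) replaced methyl rather than an aromatic ring, so it sets only a rough scale. A step beyond the scatter is not expected in this assay and neither direction is favoured. The working figure is a 1.1-fold higher number from compound 2 to compound 3 (0.05 log units; within the scatter) as the estimated step. Compound 3 is expected at an estimated 20000 nM (range 8000 nM to 50000 nM).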

Compound 3, half-maximal inhibitory concentration: 33400 nM
Compound 3: the middle estimate sits 1.7-fold (0.22 log units) below what was measured; measured number inside the range.
By their numbers in this assay, from the lowest: compounds 2, 3 and 1 (each within the scatter of the next, the first and the last beyond it).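

In this assay, a 1.9-fold higher number from compound 2 to compound 3 (0.27 log units; within the scatter) stays within the scatter, so on this carbonyl carbon 4-methylphenyl and pyridin-4-yl cannot be told apart, even though the exchange removes the ring nitrogen and adds a methyl group. a 1.1-fold lower number from compound 1 to compound 3 (0.06 log units; within the scatter) is also within the scatter, so compound 3 goes against any reading that a six-membered aromatic ring on this carbonyl carbon is enough to separate a compound from compound 1: only pyridin-4-yl gives a step beyond the scatter, a 2.1-fold lower number from compound 1 to compound 2 (0.32 log units; beyond the scatter), and compound 3 lies within the scatter of both neighbours. No available data explain this behaviour of the series.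

The compounds shown leave open whether the ring nitrogen or the methyl group on the ring matters at all, as the two change together in a single step and an unsubstituted phenyl group would be needed to separate them. Also open, on these data alone, is how a pyridin-3-yl group, a longer alkyl chain or a ring bearing an amine or a carboxylic acid on this carbonyl carbon would read against these three compounds.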